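A Longer Ether Side Chain at the Cytotoxicity Ceiling

The source may report more compounds than this note shows. Statements on the series, on what has been measured and on what is new or still open speak of the compounds shown alone.

Compound 1 `CC(C)COc1nn(-c2ccc(Oc3ccccc3)cc2)c(=O)o1` was tested in a functional assay on RAW264.7 cells (Mus musculus) for cytotoxicity; on this read-out lower numbers stand for higher toxicity in this test and higher numbers for lower toxicity in this test. In this assay compound 1 gives > 100000 nM, which is a limit of the assay and not a number. Compound 2 `CCCCCCCCCCCCCCCCOP1(=O)OCCC(C(=O)OC)=C(C)O1`, a structurally unrelated entry, was tested alongside it. In this assay compound 2 gives > 100000 nM, again a limit. Both entries therefore sit at the limit of > 100000 nM in this assay, at which 2 of the 2 values shown sit, and compound 1 stands at the ceiling of what this assay reports, with no measurable toxicity on the mouse macrophage cells.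

Compound 3 `O=c1oc(OCCOCc2ccccc2)nn1-c1ccc(Oc2ccccc2)cc1` carries (benzyloxy)methyl in place of isopropyl on a saturated chain carbon bound to an oxygen on an aromatic ring. Going by the values given here, no measured step between compounds is available for this change, so the expectation rests on the standing of compound 1 alone. Compound 3 is expected to show a step of a number no higher from compound 1 to compound 3 (the limit leaves the size open), that is, no change beyond the scatter. Compound 3 is estimated at 100000 nM, within a range from 30000 nM to 300000 nM, most likely reported as a limit once more.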

Compound 3, half-maximal cytotoxic concentration: > 100000 nM
Compound 3 ended at the assay's limit; the forecaster's own chance of this, stated with the estimate: 75%; the middle value lies on the limit itself.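

Compound 1 and compound 3 both stand at a limit of this assay, not at a number, so no step can be read between them: the limit of > 100000 nM in this assay, at which 3 of the 3 values shown sit.

The compounds shown leave open whether (benzyloxy)methyl in place of isopropyl changes toxicity at all, and at what concentration either compound would harm these cells.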